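This account rests on a few compounds, and the source may have more. Where it says the series, first, only, none or still open, it means among the compounds named here.

Measured so far in an ADME assay for acid dissociation:
- compound 1 `O=C(c1ccc(C(F)(F)F)cc1)N1CCC(=Cc2ccc(C3=NCCO3)cc2)CC1`: 4.7
- compound 2 `O=C(C1CCN(c2ccncc2)CC1)N1CCN(S(=O)(=O)c2ccc(Br)cc2)CC1`: 9.2
- compound 3 `O=C(C1CCN(c2ccncn2)CC1)N1CCN(S(=O)(=O)c2ccc(Br)cc2)CC1`: 6.1

Compound 3 holds the second highest number of the three, lying under compound 2 and over compound 1.

The next compound is compound 4 `Cc1nccc(N2CCC(C(=O)N3CCN(S(=O)(=O)c4ccc(Br)cc4)CC3)CC2)n1`. It has methyl in place of hydrogen on an aromatic carbon, taking pyrimidin-4-yl to 2-methylpyrimidin-4-yl, with the new group between two ring nitrogen atoms: methyl in place of hydrogen on an aromatic carbon.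

Within the data shown here, only one measured step bears on this, and only indirectly: a number 3.10 log units lower from compound 2 to compound 3 (beyond the scatter). That large step exchanged pyridin-4-yl for pyrimidin-4-yl, whereas here the ring stays and only a methyl is added. Among the measured compounds shown here, no measured step shows what a methyl does on such a ring, so the direction is a judgement and not a trend in the data. A modest rise in this assay is expected, far smaller than the step measured into compound 3.

The expected step is a number 0.60 log units higher from compound 3 to compound 4 (beyond the scatter).

Compound 4 is estimated at 6.7, with an expected range of 6.2 to 7.3.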

Compound 4, acid dissociation constant: 7.2
Compound 4: middle estimate off by 0.50 log units, on the low side; measured number inside the range.
By their numbers in this assay, from the lowest: compound 1; then compound 3; then compound 4; then compound 2.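

In this assay, the series now has its first substituent change on this ring with the ring itself kept: methyl in place of hydrogen, between two ring nitrogen atoms, gives a number 1.10 log units higher from compound 3 to compound 4 (beyond the scatter). A single added carbon at this position therefore moves the number by a large step, and the change out of pyridin-4-yl now reads a number 2.00 log units lower from compound 2 to compound 4 (beyond the scatter), so 2-methylpyrimidin-4-yl sits in the gap between the pyrimidin-4-yl and pyridin-4-yl compounds. Nothing measured here speaks to the origin of this rise.

On these data alone, whether an ethyl group, a methoxy group or an amine in the same place would move the number further, or in the opposite direction, stays open. Also open is whether a methyl on the pyridin-4-yl ring would give a step of similar size, since this is the only methyl step shown.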